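A few compounds are considered here, and "the series" means these few. Any claim that something is new, unique, unknown or untested is made for them only; others in the source may bear on it.

Working notes on the series. The three measured compounds share one core and differ in the group on it. Compound 1 `Cc1c(-c2cc(-c3ccccc3Cl)no2)cnn1C1CCNCC1` gives 71% in an assay on a protein complex for positive allosteric modulation of Neuronal acetylcholine receptor; alpha4/beta2 (Homo sapiens); on this read-out higher numbers stand for larger maximal responses and lower numbers for smaller maximal responses. Compound 2 `Cc1c(-c2cc(-c3c(F)cccc3Cl)no2)cnn1C1CCNCC1` gives 66% in this assay; the step of a number 5 percentage points lower from compound 1 to compound 2 (within the scatter) stays within the scatter. Compound 3 `Fc1ccc(Cl)c(-c2cc(-c3cnn(C4CCNCC4)c3)on2)c1` gives 29% in this assay, the lowest of the three numbers; compound 2 stands nearest to it and compound 1 furthest, both beyond the scatter above compound 3. Going by the values given here, no step is counted for either of those pairs, so only the values themselves are set side by side.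

Compound 4 `c1nn(C2CCNCC2)cc1-c1cc(C2CCCCC2)no1` is not yet measured. Its change from compound 3 is cyclohexyl in place of 2-chloro-5-fluorophenyl on an aromatic carbon. Among the compounds with values here, no measured step exchanges an aromatic ring for a non-aromatic one; the only counted step, a number 5 percentage points lower from compound 1 to compound 2 (within the scatter), concerns fluoro in place of hydrogen and lies within the scatter, so it gives no guide to size or direction here. The expectation therefore rests on the number of compound 3 alone, with a wide spread to either side. A step of a number 6 percentage points higher from compound 3 to compound 4 (within the scatter) is expected. Compound 4 is estimated at 35% in this assay, within a range from 15% to 60%.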

Compound 4, largest response reached (reported as efficacy), in percent of the reference or control that the assay uses: 16%
Estimate against measurement, compound 4: 19 percentage points above, and the stated range covers the measured number.
By their numbers in this assay, from the lowest: compound 4; then compound 3; then compounds 2 and 1 (each within the scatter of the next).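

In this assay, cyclohexyl in place of 2-chloro-5-fluorophenyl, on the aromatic carbon next to the ring nitrogen, gives a number 13 percentage points lower from compound 3 to compound 4 (beyond the scatter). Going by these compounds alone, this is the first counted step beyond the scatter, so the group at this place does move the maximal response, which the one earlier step, a fluoro in place of hydrogen, could not show. Because the leaving group differs from cyclohexyl both in its aromatic ring and in its chlorine and fluorine, this single pair cannot separate the ring from the halogens, and no measurement at hand bears on the reason for the lower number.

The compounds shown leave open whether a plain phenyl at this place would stand with compound 3 or with compound 4, and whether an open chain such as isopropyl or a ring amine such as morpholine would be tolerated there. They also leave open whether the same exchange would give a step of similar size on the core of compound 1, with its methyl group and its higher number.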